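Chloro in place of hydrogen on compound 2

The compounds below may be only part of what the source reports. "The series", "measured", "known", "first", "only" and "open" are said of these compounds alone.

In a functional assay on Jurkat cells (Homo sapiens) for cytotoxicity, read by luminescence and CellTiter-Glo, with a stated time of 3 days (on this read-out lower numbers stand for stronger inhibition and higher numbers for weaker inhibition), compound 1 (`O=C(Nc1ccc(Cl)cc1Cl)c1cc(F)ccc1O`) gives 880 nM and compound 2 (`O=C(Nc1ccc([N+](=O)[O-])cc1)c1cc(F)ccc1O`) gives 940 nM. These two values lie within the usual scatter of each other, so compound 2 stands level with compound 1 on the numbers available. For compound 3 (`O=C(Nc1ccccc1)c1cc(F)ccc1O`) the entry is "not determined" (no result reported), which leaves no number for comparison.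

Compound 4 (`O=C(Nc1ccc([N+](=O)[O-])cc1Cl)c1cc(F)ccc1O`) differs from compound 2 by chloro in place of hydrogen on an aromatic carbon. The change is a chloro in place of hydrogen on an aromatic carbon, ortho to a large group and meta to a nitro group.

Among the measured compounds shown here, no measured pair shows this change alone, so the size of the step in this assay rests on little evidence. The estimated step of a 1.9-fold lower number from compound 2 to compound 4 (0.27 log units; within the scatter) is expected to be modest and towards stronger inhibition. For compound 4 the expected value is 500 nM, with an estimated range of 150 nM to 1400 nM.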

Compound 4, half-maximal inhibitory concentration: 530 nM
Estimate against measurement, compound 4: 1.1-fold (0.03 log units) below, within the range that was stated.
By their numbers in this assay, from the lowest: compounds 4, 1 and 2 (each within the scatter of the next).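

In this assay, chloro in place of hydrogen on the aromatic carbon ortho to a large group and meta to a nitro group gives a 1.8-fold lower number from compound 2 to compound 4 (0.25 log units; within the scatter), so in compound 4 this position carries a chloro with no step beyond the scatter. The second pair, nitro in place of chloro on an aromatic carbon, gives a 1.7-fold lower number from compound 1 to compound 4 (0.22 log units; within the scatter), so these two groups cannot be told apart on this read-out either, with the chloro on the position ortho to a large group present in both compounds. The compounds shown offer no measurement that would explain either step.

Steps to compound 3 cannot be read, as it has no number, so the effect of these groups relative to the core of compound 3 remains unknown. Also open, on these data alone, is whether an amine or a carboxylic acid in place of the chloro of compound 4 would give a step beyond the scatter.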